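Swapping the aryl on a piperazine amide

The source may report more compounds than this note shows. Statements on the series, on what has been measured and on what is new or still open speak of the compounds shown alone.

Three amides built on one shared core have been tested in an assay on brain for inhibition of Fatty-acid amide hydrolase 1 (Rattus norvegicus), read by scintillation counting, with a stated time of 10 min; on this read-out lower numbers stand for stronger inhibition and higher numbers for weaker inhibition. Compound 1 `CC(C)Cc1ccc(C(C)C(=O)NCc2ccccc2Cl)cc1` gives 4100 nM, and compound 2 `CC(C)Cc1ccc(C(C)C(=O)NCc2cc(Cl)ccc2Cl)cc1` gives 4400 nM. Compound 3 `CC(C)Cc1ccc(C(C)C(=O)N2CCN(c3ccc(Cl)cc3)CC2)cc1` gives 1700 nM, the lowest of the three numbers; its gaps to compound 1 and to compound 2 both lie beyond the scatter, so it is the strongest inhibitor of the three.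

Compound 4 `Cc1cccc(N2CCN(C(=O)C(C)c3ccc(CC(C)C)cc3)CC2)c1C` has not been measured. It differs from compound 3 by 2,3-dimethylphenyl in place of 4-chlorophenyl on an amine nitrogen in a ring. Within the data shown here, the only measured single change, a 1.1-fold higher number from compound 1 to compound 2 (0.03 log units; within the scatter), adds a chloro to a different aromatic ring of the shared core and stays within the scatter. Among the measured compounds shown here, no measured step alters the group on the ring nitrogen, so that step bears only weakly on compound 4. The step of a 1.2-fold higher number from compound 3 to compound 4 (0.07 log units; within the scatter) is therefore expected to be small, with no direction beyond the scatter. Compound 4 is expected to give 2000 nM in this assay, within a range from 700 nM to 6000 nM.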

Compound 4, half-maximal inhibitory concentration: 1700 nM
Estimate against measurement, compound 4: 1.2-fold (0.07 log units) above, within the range that was stated.
By their numbers in this assay, from the lowest: compounds 3 and 4 (each within the scatter of the next); then compounds 1 and 2 (each within the scatter of the next).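

Among these compounds, until now, no measured step had touched the aryl group on an amine nitrogen in a ring. In this assay, putting 2,3-dimethylphenyl in place of 4-chlorophenyl at this position gives no change at the digits printed from compound 3 to compound 4 (within the scatter), so an aryl group without chlorine reads the same here as the chlorinated one, even with its different substitution. No available measurement explains why these two groups read alike.

As far as these compounds go, it remains open whether a plain phenyl, or an aryl ring carrying a carboxylic acid or an amine, would also leave the number unchanged. This single step replaces the 4-chloro substitution with the 2,3-dimethyl substitution in one move, so it cannot show what each methyl contributes alone.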